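Swapping bromo for methoxy on a weak cytotoxic series

The compounds below may be only part of what the source reports. "The series", "measured", "known", "first", "only" and "open" are said of these compounds alone.

Measured in a functional assay on IMR-32 cells (Homo sapiens) for cytotoxicity, read by sulforhodamine B assay, with a stated time of 48 h; a lower number here means a stronger inhibitor, a higher number a weaker inhibitor
- compound 1 `CC(=O)N1N=C(c2ccc(Br)cc2)CC1c1ccccc1` gives 22400 nM
- compound 2 `CC(=O)N1N=C(c2ccco2)CC1c1ccccc1[N+](=O)[O-]` gives 27900 nM
- compound 3 `CC(=O)N1N=C(c2ccco2)CC1c1ccc(Br)cc1` gives 47800 nM

In this assay compound 3 gives 47800 nM and sits within the usual scatter of compound 2 at 27900 nM while compound 1 at 22400 nM has a lower number, beyond the scatter. Compound 4 `COc1ccc(C2CC(c3ccco3)=NN2C(C)=O)cc1` is not yet measured. Set against compound 3 it shows methoxy in place of bromo on an aromatic carbon with methoxy in place of bromo on an aromatic carbon. For the measured compounds named here, no measured pair shows this swap, so the guide is only the modest spread of the three values. The expected move is a 1.4-fold lower number from compound 3 to compound 4 (0.14 log units; within the scatter) and it is a slightly lower number, not expected to pass beyond the scatter. Compound 4 is estimated to give 35000 nM with 15000 nM to 80000 nM as its expected range.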

Compound 4, half-maximal inhibitory concentration: 14500 nM
Estimate against measurement, compound 4: 2.4-fold (0.38 log units) above; the measured number lies below the stated range.
By their numbers in this assay, from the lowest: compounds 4, 1, 2 and 3 (each within the scatter of the next, the first and the last beyond it).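

For the compounds shown here, this is the first pair here that differs in only one place, and it shows that the group on this aromatic carbon matters in this assay: methoxy in place of bromo gives a 3.3-fold lower number from compound 3 to compound 4 (0.52 log units; beyond the scatter). The step is beyond the scatter and points towards a stronger inhibitor, so a single swap at this position can shift the result. Nothing available explains why this swap has this effect.

From the compounds shown here alone, whether an amine, a hydroxyl or a chloro on the same carbon would match methoxy remains open. Also open, going by these compounds, is whether the same swap would give a similar step in compound 1, which also carries bromo.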